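The compounds below may be only part of what the source reports. "The series", "measured", "known", "first", "only" and "open" are said of these compounds alone.

Values in a functional assay on SGC-7901 cells (Homo sapiens) for antiproliferative activity, read by MTT assay, with a stated time of 72 h; a lower number here means a stronger inhibitor, a higher number a weaker inhibitor:
compound 1 `CCOc1ccc(-c2ccc3ncn(-c4cc(OC)c(OC)c(OC)c4)c3c2)cc1`: 2970 nM
compound 2 `COc1ccccc1-c1ccc2ncn(-c3cc(OC)c(OC)c(OC)c3)c2c1`: 5050 nM

Among the measured compounds shown here, with only these two values, compound 2 stands within the scatter of compound 1, its sole neighbour. Compound 3 `COc1cc(-n2cnc3ccc(-c4ccc(C(C)=O)cc4)cc32)cc(OC)c1OC` is not yet measured. It carries 4-acetylphenyl in place of 2-methoxyphenyl on an aromatic carbon of the shared core: 4-acetylphenyl in place of 2-methoxyphenyl on an aromatic carbon. For the measured compounds named here, one measured step bears on this change, as it exchanges a substituted phenyl at the same place: a 1.7-fold higher number from compound 1 to compound 2 (0.23 log units; within the scatter). Going by the values given here, no measured compound carries 4-acetylphenyl, so the evidence is indirect. That single step gives no reason to expect a change beyond the scatter in this assay, and no direction is supported. The expected step is a 1.3-fold lower number from compound 2 to compound 3 (0.10 log units; within the scatter). The estimate for compound 3 is 4000 nM, with an expected range of 1500 nM to 11000 nM.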

Compound 3, half-maximal inhibitory concentration: 450 nM
Compound 3: the middle estimate sits 8.9-fold (0.95 log units) above what was measured, and the stated range ends above it.
By their numbers in this assay, from the lowest: compound 3; then compounds 1 and 2 (each within the scatter of the next).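

In this assay, the group on this aromatic carbon of the shared core proves able to move the number, which the earlier exchange of substituted phenyls did not show. 4-Acetylphenyl in place of 2-methoxyphenyl gives an 11-fold lower number from compound 2 to compound 3 (1.05 log units; beyond the scatter), and acetyl in place of ethoxy gives a 6.6-fold lower number from compound 1 to compound 3 (0.82 log units; beyond the scatter), so compound 3 stands apart from both earlier compounds, each step beyond the scatter. No measured evidence on these compounds accounts for this difference.

The compounds shown leave open whether the gain belongs to the acetyl group itself, since nothing here tells how 2-acetylphenyl, a longer propanoyl chain, a carboxylic acid or an amine at this place would compare. On these data alone, whether the same order holds in any other cell line also remains open.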